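This account rests on a few compounds, and the source may have more. Where it says the series, first, only, none or still open, it means among the compounds named here.

Compound 1 `Nc1n[nH]c(N)c1/N=N/c1cccc[n+]1[O-]`: 62600 nM
Compound 2 `Cn1nc(N)c(/N=N/c2ccncc2)c1N`: 67400 nM
Compound 3 `Nc1n[nH]c(N)c1/N=N/c1ccc(O)cc1`: 33000 nM

These three values come from a functional assay on K562 cells (Homo sapiens) for cytotoxicity, read by fluorescence, with a stated time of 72 h (a higher number here means a weaker inhibitor, a lower number a stronger inhibitor), and lie close together. Compound 3 stands within the scatter of compound 1. Against compound 2 it has the lower number, by a gap that only just passes the scatter.

Compound 4 `CC(=O)n1nc(N)c(/N=N/c2ccc(O)cc2)c1N` is compound 3 with acetyl in place of hydrogen on an aromatic nitrogen, and it has not yet been measured. Within the data shown here, no pair of measured compounds shows this change, so the data offer no direct guide to its size or direction. The only ground for an expectation is the narrow spread of the measured series, which runs from compound 3 at 33000 nM to compound 2 at 67400 nM and so stays small across the structures at hand. In this assay the expected step is a 1.1-fold lower number from compound 3 to compound 4 (0.04 log units; within the scatter), an estimate that amounts to no change beyond the scatter. Compound 4 is therefore estimated at 30000 nM, with an expected range from 12000 nM to 80000 nM as the wide margin for an untested change.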

Compound 4, half-maximal inhibitory concentration: 64900 nM
Compound 4: the middle estimate sits 2.2-fold (0.34 log units) below what was measured; the measured number falls inside the stated range.
By their numbers in this assay, from the lowest: compounds 3, 1, 4 and 2 (each within the scatter of the next, the first and the last beyond it).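

In this assay, among these compounds, the only step that can be read is a 2.0-fold higher number from compound 3 to compound 4 (0.29 log units; within the scatter), with acetyl in place of hydrogen on an aromatic nitrogen of the five-membered ring. Among the compounds shown here, the earlier compounds included no pair differing in one place, so this is the first direct reading at this nitrogen, and it shows that putting acetyl there does not move the number beyond the scatter, although the step lies close to that limit and cannot be read as a real loss. Nothing measured here offers an explanation for the size of this step.

As far as these compounds go, it remains open whether a longer acyl chain such as butanoyl, an aromatic acyl group such as benzoyl or a sulfonyl group such as methanesulfonyl on the same nitrogen would produce a step beyond the scatter. For the compounds shown here, with only one pair carrying this change, it is also open whether acetyl would give a similar step on the core of compound 1, which bears a different group on the azo link.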